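A few compounds are considered here, and "the series" means these few. Any claim that something is new, unique, unknown or untested is made for them only; others in the source may bear on it.

Three esters built on one shared core have been tested so far: compound 1 `COc1cc(OC)c(OC)cc1/C=C/COC(=O)/C=C/c1c(OC)ccc(OC)c1OC`, compound 2 `COc1cc(OC)c(OC)cc1/C=C/COC(=O)/C=C/c1ccc(Br)cc1` and compound 3 `COc1cc(OC)c(OC)cc1/C=C/COC(=O)/C=C/c1cc(OC)c(OC)c(OC)c1`. In a functional assay on the whole organism (strain Kunming) with Mus musculus as the target, with a stated time of 0.5 h, at a dose of 300 mg/kg by the intraperitoneal route (on this read-out higher numbers stand for a weaker effect at the one dose given and lower numbers for a stronger effect), compound 1 gives 100%. In this assay compound 2 gives 100%, while compound 3 gives 100%. Compound 2 therefore stands level with compound 1 and compound 3 at the digits shown: its nearest neighbour is compound 1 and its furthest is compound 3, and to both there is no change within the scatter. No two of these compounds differ in only one place, so no single-point step between measured compounds can be described.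

Compound 4 `COc1cc(OC)c(OC)cc1/C=C/COC(=O)/C=C/c1ccccc1Cl` has not yet been measured. It differs from compound 2 in one respect: 2-chlorophenyl in place of 4-bromophenyl on a double-bonded chain carbon bound to a double-bonded chain carbon. Because compound 2 gives 100% and compound 3, which carries a different ring at that position, gives 100%, the change of one halogen-bearing ring for another is expected to leave the reading unchanged. The step from compound 2 to compound 4 is estimated as no change at the digits printed from compound 2 to compound 4 (within the scatter), with nothing beyond the scatter expected. Compound 4 is expected to give 100% in this assay, between 85% and 100%.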

Compound 4, a percentage reported as activity, at one dose (the size of the read-out at that dose, not a potency): 100%
Compound 4: the middle estimate sits on the measured number at the digits printed; low and high end bracket the measured number.
By their numbers in this assay, from the lowest: compounds 1, 2, 3 and 4 (each within the scatter of the next).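

In this assay, for the compounds shown here, the pair gives the first reading of a single change: putting 2-chlorophenyl in place of 4-bromophenyl on a double-bonded chain carbon bound to a double-bonded chain carbon gives no change at the digits printed from compound 2 to compound 4 (within the scatter). Two things change together here, the halogen and the number in the group's name that tells where it sits on the ring, and at this one dose the pair shows no difference from either or both, though this single step cannot separate the two. Nothing available explains why the reading stays level, and no measurement of any property of these groups bears on it.

The compounds shown leave open whether anything other than a halogen-bearing phenyl at this position, such as a phenyl carrying an amine or a carboxylic acid, or a longer chain in place of the ring, would move the reading at all. As far as these compounds go, the read-out is also the size of the effect at a single dose and not a potency, so whether compound 2 and compound 4 would stay level at other doses remains unknown.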